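The source may hold more compounds than are shown below. What is called first, only, known or untested is meant among the compounds shown, and "the series" means these compounds.

Within the data shown here, in a functional assay on FM3A cells (Mus musculus) for antiproliferative activity, with a stated time of 48 h (on this read-out lower numbers stand for stronger inhibition and higher numbers for weaker inhibition), compound 3 (`Nc1ccc(/C=C/C(=O)c2ccccc2)cc1`) gives 146000 nM, the highest of the three numbers so far. Compound 1 (`C=C(Br)C(=O)Nc1ccc(/C=C/C(=O)c2ccccc2)cc1`) gives 3900 nM, and compound 2 (`C=C(Br)C(=O)Nc1ccc(/C=C/C(=O)c2cccc(OC)c2)cc1`) gives 2700 nM. Compound 4 (`Cc1ccc(C(=O)/C=C/c2ccc(N)cc2)cc1`) differs from compound 3 in one place: methyl in place of hydrogen on an aromatic carbon, para to a large group. The closest measured precedent is a 1.4-fold lower number from compound 1 to compound 2 (0.16 log units; within the scatter), methoxy in place of hydrogen on an aromatic carbon, and it involves a different group on a different parent. The large 37-fold higher number from compound 1 to compound 3 (1.57 log units; beyond the scatter) concerns the substituent on nitrogen, which is untouched here. No step beyond the scatter is therefore expected in this assay. The estimated step is a 1.1-fold lower number from compound 3 to compound 4 (0.05 log units; within the scatter). Compound 4 is expected at 130000 nM, with an estimated range of 55000 nM to 300000 nM.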

Compound 4, half-maximal inhibitory concentration: 107000 nM
The estimate for compound 4 lay 1.2-fold (0.08 log units) above the measured number, within the range that was stated.
By their numbers in this assay, from the lowest: compounds 2 and 1 (each within the scatter of the next); then compounds 4 and 3 (each within the scatter of the next).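

In this assay, methyl in place of hydrogen on an aromatic carbon, para to a large group, gives a 1.4-fold lower number from compound 3 to compound 4 (0.13 log units; within the scatter) on the parent with hydrogen on the nitrogen. Among these compounds, the earlier step on this ring, methoxy in place of hydrogen, belonged to the parent carrying (1-bromoethenyl)carbonyl on nitrogen, so this is the first reading on the parent without that group. No measured evidence bears on this result.

On these data alone, whether methyl behaves alike on the parent of compound 1 stays open. So does the effect of a carboxylic acid or an amine at this place.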